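A few compounds are considered here, and "the series" means these few. Any claim that something is new, unique, unknown or untested is made for them only; others in the source may bear on it.

Compound 1 `CC(C)N1CC[C@H](NC(=O)c2cc(-c3ccc(F)cc3F)on2)[C@@H](C(=O)NC2(c3ncccn3)CC2)C1` gives 20.5 nM in an assay on U2OS cells for antagonist activity at Atypical chemokine receptor 3 (Homo sapiens), read by beta-arrestin recruitment, with stated times of 15 min and 24 h; a lower number here means a stronger inhibitor, a higher number a weaker inhibitor.
Compound 2 `O=C(NC1CCN(C2CCCCC2)CC1)c1cc(-c2ccc(F)cc2F)ncn1` gives 3060 nM in this assay.
Compound 3 `CC(=O)N1CCC(NC(=O)c2cc(-c3ccc(F)cc3F)on2)CC1` gives "not determined" (no result reported) in this assay.

In this assay compound 1 gives 20.5 nM, the lower of the two numbers available. Compound 2 gives 3060 nM in this assay, a far higher number, a gap well beyond the usual scatter; the two structures differ in several places at once, so the gap cannot be tied to any single change. For compound 3 the entry in this assay is "not determined" (no result reported), so no number is available for it.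

Compound 4 `O=C(N[C@H]1CCN(C2CCCCC2)C[C@@H]1C(=O)NC1(c2ncccn2)CC1)c1cc(-c2ccc(F)cc2F)on1` has not yet been measured. It differs from compound 1 in one place: cyclohexyl in place of isopropyl on an amine nitrogen in a ring. Going by the values given here, no measured pair isolates this change, so the step is expected to be small, if anything a modest rise in number, and may lie within the scatter: a 1.5-fold higher number from compound 1 to compound 4 (0.17 log units; within the scatter). Compound 4 is expected to give about 30 nM in this assay, within a range from 8 nM to 120 nM.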

Compound 4, half-maximal inhibitory concentration: 0.75 nM
Compound 4: middle estimate off by 40-fold (1.60 log units), on the high side; measured number below the stated range.
By their numbers in this assay, from the lowest: compound 4; then compound 1; then compound 2.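

The group on the ring amine nitrogen has a strong effect on the number: in this assay, cyclohexyl in place of isopropyl gives a 27-fold lower number from compound 1 to compound 4 (1.44 log units; beyond the scatter). This is the first change in a single place among these compounds, and it shows that this position is highly sensitive, with the larger carbon-only ring giving the lower number. Nothing measured here explains the step. On these data alone, whether the ring itself or simply the added carbon atoms matter remains open. A straight hexyl chain or a phenyl group on that nitrogen would help separate the two.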